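This account rests on a few compounds, and the source may have more. Where it says the series, first, only, none or still open, it means among the compounds named here.

The account concerns two pairs of compounds tested in an assay on COS-7 cells for inhibition of patatin-like phospholipase domain-containing protein 2 (Mus musculus); a lower number here means a stronger inhibitor, a higher number a weaker inhibitor. Compound 1 `CCOC(=O)c1cccc(-c2ccc(OCC)c([N+](=O)[O-])c2)c1` and compound 2 `CCOC(=O)c1cccc(-c2ccc(OCC)c(N)c2)c1` share one core, and in this assay compound 1 gives 200000 nM while compound 2 gives 140000 nM; the change between them, (amino in place of nitro on an aromatic carbon), made a step of a 1.4-fold lower number from compound 1 to compound 2 (0.15 log units; within the scatter). Compound 3 `CN(C)c1ccc(-c2cccc([N+](=O)[O-])c2)cc1` rests on a different core, and the difference between the two cores is not broken down here. For compound 3 the assay reports only a limit, > 200000 nM, and the limit of > 200000 nM in this assay, at which 1 of the 3 values shown sits, describes that limit. Compound 4 `CN(C)c1ccc(-c2cccc(N)c2)cc1` has not yet been measured; it differs from compound 3 by amino in place of nitro on an aromatic carbon. This is the same kind of change as that from compound 1 to compound 2, though the surroundings differ: in compound 2 the amino sits ortho to an ethoxy group and meta to a large group, whereas in compound 4 it sits meta to a group of 9 heavy atoms. Since the earlier step of a 1.4-fold lower number from compound 1 to compound 2 (0.15 log units; within the scatter) stayed within the scatter, the step from compound 3 to compound 4 is expected to be about a number no higher from compound 3 to compound 4 (the limit leaves the size open). Compound 4 is therefore estimated at 200000 nM, between 100000 nM and 400000 nM, with a fair chance that only a limit is reported again.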

Compound 4, half-maximal inhibitory concentration: 100000 nM
For compound 4 the middle estimate is 2.0-fold (0.30 log units) above the measured one; the range from low to high includes it.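

In this assay, putting amino in place of nitro on the core of compound 3 gave an at least 2.0-fold lower number from compound 3 to compound 4 (0.30 log units; that floor lies within the scatter). Set beside the same change on the core of compound 1, this gives no sign so far that the change behaves differently from one core to the other, though it does not show that it behaves alike: the same change on two cores in this assay, a 1.4-fold lower number (0.15 log units; within the scatter) from compound 1 to compound 2 and an at least 2.0-fold lower number (0.30 log units; that floor lies within the scatter) from compound 3 to compound 4; the limit leaves it open whether they differ. For compound 3 the assay gives only > 200000 nM, which is a limit and not a number, so the second step has a floor but no known size, and the two pairs cannot establish that the change carries across cores with the same size.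

The compounds shown leave open whether a group other than amino or nitro on that aromatic carbon, such as a carboxylic acid or an acetamide, would shift the number beyond the scatter. They also leave open what a carboxylic acid in place of the ethyl ester of compound 2, or a longer chain in place of its ethoxy group, would do in this assay.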